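Working notes: 2-chlorobenzyl to 4-chlorobenzyl on compound 3

The source may report more compounds than this note shows. Statements on the series, on what has been measured and on what is new or still open speak of the compounds shown alone.

Measured so far in a functional assay on HepG2 cells (Homo sapiens) for antiproliferative activity, read by MTT assay, with a stated time of 48 h; on this read-out higher numbers stand for weaker inhibition and lower numbers for stronger inhibition:
- compound 1 (`Fc1ccc(CSc2nnc(-c3cnccn3)s2)c(F)c1`) gives 9630 nM
- compound 2 (`c1ccc(CSc2nnc(-c3cnccn3)s2)cc1`) gives 11400 nM
- compound 3 (`Clc1ccccc1CSc1nnc(-c2cnccn2)n1-c1ccccc1`) gives 18800 nM

Compound 3 at 18800 nM stands within the usual scatter of both compound 2 and compound 1, and those two also lie within the scatter of each other. The three numbers therefore carry no ranking. Within the data shown here, no two measured compounds differ in one place only, so the series offers no measured step to serve as a guide.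

The next compound is compound 4 (`Clc1ccc(CSc2nnc(-c3cnccn3)n2-c2ccccc2)cc1`), which has the same atoms as compound 3, joined differently. The difference is 4-chlorophenyl in place of 2-chlorophenyl on a saturated chain carbon bound to a sulfur and amounts to 4-chlorophenyl in place of 2-chlorophenyl on a saturated chain carbon bound to a sulfur. The rest of the structure is unchanged.

Among the measured compounds shown here, with no measured precedent for this change, the expectation rests on compound 3 at 18800 nM and on the narrow spread of the three numbers. No step beyond the scatter is expected in this assay, in either direction. The expected step is a 1.3-fold lower number from compound 3 to compound 4 (0.10 log units; within the scatter) and it should stay inside the scatter. Compound 4 is estimated at 15000 nM with an expected range of 7500 nM to 30000 nM for repeat measurements.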

Compound 4, half-maximal inhibitory concentration: 15300 nM
Compound 4: the middle estimate sits 1.0-fold (0.01 log units) below what was measured; measured number inside the range.
By their numbers in this assay, from the lowest: compounds 1, 2, 4 and 3 (each within the scatter of the next).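

Compound 3 and compound 4 give the series its first comparison that differs in one place only: 4-chlorophenyl in place of 2-chlorophenyl on a saturated chain carbon bound to a sulfur. In this assay this change gives a 1.2-fold lower number from compound 3 to compound 4 (0.09 log units; within the scatter) and stays within the usual scatter, so the read-out does not separate these two chlorobenzyl isomers, and the position of the chlorine on this ring has no measurable effect here. No measurement of any other property bears on this result, and the data offer no account of it.

On these data alone, whether a carboxylic acid or a dimethylamino group in place of the chlorine, or a longer chain between the sulfur and the aromatic ring, would give a step beyond the scatter remains open. Compound 1 and compound 2 each differ from compound 3 and compound 4 in more than one place, so the compounds shown leave the contribution of the phenyl group on the core of compound 3 and compound 4 unresolved.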